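The source may report more compounds than this note shows. Statements on the series, on what has been measured and on what is new or still open speak of the compounds shown alone.

Measured compounds:
Compound 1, `CCC(CC)N(CCN(C)C(=O)CCC(=O)O)Cc1cccc(C(=O)Nc2sc3c(c2C(=O)c2cnn(-c4ccc(Cl)c(C(F)(F)F)c4)c2)CCC(C)(C)C3)c1` — in an assay on isolated protein for inhibition of sodium-dependent phosphate transport protein 2B (Homo sapiens) (a lower number here means a stronger inhibitor, a higher number a weaker inhibitor), compound 1 gives 38 nM.
Compound 2, `CCC(CC)N(CCN(C)C(=O)CCC(=O)O)Cc1cccc(C(=O)Nc2sc3c(c2C(=O)c2cnn(-c4ccc(Cl)cc4)c2)CCCC3)c1` — in this assay compound 2 gives 118 nM.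
Compound 3, `CCC(CC)N(CCN(C)C(=O)CCC(=O)O)Cc1cccc(C(=O)Nc2sc3c(c2C(=O)c2cnn(-c4ccc(Cl)cc4)c2)CCN(C(C)=O)C3)c1` — in this assay compound 3 returns only a limit, > 1000 nM.

Compound 1 and compound 2 differ from each other in more than one place, and no single step between them is recorded; their values simply stand side by side as shown. Compound 3 is a different matter. Its result is not a number but the upper limit of the assay, (the limit of > 1000 nM in this assay, at which 1 of the 3 values shown sits), so compound 3 stands at the weak end of what this set shows, with no finer position known.

Compound 4, `CCC(CC)N(CCN(C)C(=O)CCC(=O)O)Cc1cccc(C(=O)Nc2sc3c(c2C(=O)c2cnn(-c4ccc(Cl)cc4)c2)CCN(S(C)(=O)=O)C3)c1`, is the next compound. Relative to compound 3 the change is methylsulfonyl in place of acetyl on an amine nitrogen in a ring, a methylsulfonyl in place of acetyl on an amine nitrogen in a ring. Since compound 3 sits at a limit, the step from compound 3 to compound 4 cannot be sized against a measured starting number; it is expected to be a step that the limit leaves unreadable from compound 3 to compound 4, which is to say compound 4 is expected to remain at or near the limit. Compound 4 is estimated at 2000 nM, within a range from 500 nM to 8000 nM.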

Compound 4, half-maximal inhibitory concentration: 2490 nM
Estimate against measurement, compound 4: 1.2-fold (0.10 log units) below; measured number inside the range.
By their numbers in this assay, from the lowest: compound 1; then compound 2; then compound 4.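

No size can be read for the change from compound 3 to compound 4, because the result for compound 3 is a limit and not a number: the limit of > 1000 nM in this assay, at which 1 of the 4 values shown sits.

The compounds shown leave open how large the effect of methylsulfonyl in place of acetyl on an amine nitrogen in a ring actually is.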